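Hydroxylated Ethylamino Chain in Place of the Diamine

This account rests on a few compounds, and the source may have more. Where it says the series, first, only, none or still open, it means among the compounds named here.

Three compounds share one core and differ only in the group attached to a single aromatic carbon. Compound 1 `CCCCCCCCCCc1ccc(-c2noc(CCCNC)n2)cc1` gives 45% in an assay on HeLa cells for inhibition of sphingosine-1-phosphate transporter SPNS2 (Mus musculus), read by LC-MS, tested at 2 uM; on this read-out lower numbers stand for less inhibition and higher numbers for more inhibition at the one concentration tested (going by the name of the read-out). Compound 2 `CCCCCCCCCCc1ccc(-c2noc([C@@H]3CCCN3)n2)cc1` gives 21% in this assay, and compound 3 `CCCCCCCCCCc1ccc(-c2noc([C@@H](N)CCN)n2)cc1` gives 14% in this assay. Compound 3 stands lowest of the three: it lies within the scatter of compound 2, with the step of a number 7 percentage points lower from compound 2 to compound 3 (within the scatter), but clearly apart from compound 1, with the step of a number 31 percentage points lower from compound 1 to compound 3 (beyond the scatter).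

Compound 4 `CCCCCCCCCCc1ccc(-c2noc(CC(O)CNCC)n2)cc1` has not yet been measured. It differs from compound 3 in one place: 3-(ethylamino)-2-hydroxypropyl in place of 1,3-diaminopropyl on an aromatic carbon. Among the compounds with values here, no measured step carries exactly this change, so the expectation rests on the comparison with compound 1, whose 3-(methylamino)propyl group gives the highest value seen, and on the step of a number 31 percentage points lower from compound 1 to compound 3 (beyond the scatter), which shows how far the 1,3-diaminopropyl group sits below it. Within the data shown here, because compound 1 gives 45% with a chain of related make-up, compound 4 is expected to move back upward from compound 3, by a number 21 percentage points higher from compound 3 to compound 4 (beyond the scatter), though no measured compound carries the 3-(ethylamino)-2-hydroxypropyl group itself. Compound 4 is therefore estimated at 35%, with a range from 15% to 55%.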

Compound 4, a percentage reported as inhibition, at one concentration (the size of the read-out at that concentration, not a potency): 5%
Estimate against measurement, compound 4: 30 percentage points above; the measured number lies below the stated range.
By their numbers in this assay, from the lowest: compounds 4, 3 and 2 (each within the scatter of the next, the first and the last beyond it); then compound 1.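

The result shows that a close likeness to the 3-(methylamino)propyl chain does not keep the number up in this assay: the new chain adds a hydroxyl and carries ethyl on the nitrogen in place of methyl, and the step is a number 40 percentage points lower from compound 1 to compound 4 (beyond the scatter). The hydroxylated chain also falls short of the pyrrolidin-2-yl group, with a number 16 percentage points lower from compound 2 to compound 4 (beyond the scatter), yet it cannot be told apart from the 1,3-diaminopropyl group, with a number 9 percentage points lower from compound 3 to compound 4 (within the scatter), so three different groups at this position now all stand well under compound 1. Nothing available explains why this small change in the chain has so large an effect.

Since compound 4 differs from compound 1 in both the hydroxyl and the ethyl group, the compounds shown do not say which of the two accounts for the step, and a 3-(ethylamino)propyl group or a 3-(methylamino)-2-hydroxypropyl group would separate them. As far as these compounds go, it also stays open whether the two mirror-image forms of the hydroxyl-bearing carbon behave alike, as compound 4 has no defined stereocentre there.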